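The source may hold more compounds than are shown below. What is called first, only, known or untested is meant among the compounds shown, and "the series" means these compounds.

Compound 1 `CCO/N=C/Nc1cc(Cl)c(CC)c(Cl)c1`, compound 2 `CCCOc1c(Cl)cc(N/C=N/OCC)cc1Cl` and compound 3 `C#CCc1c(Cl)cc(N/C=N/OCC#N)cc1Cl` have been measured in a physicochemical assay for lipophilicity, measured as octanol-water partition; a higher number here means a more lipophilic compound, a lower number a more polar compound. Among the measured compounds shown here, compound 1 gives 4.8 and compound 2 gives 4.6; the only measured step, a number 0.20 log units lower from compound 1 to compound 2 (within the scatter), is small. Compound 3 gives 3, the lowest of the three, with compound 2 the nearest of the others and compound 1 the furthest. Compound 4 `C#CCc1c(Cl)cc(N/C=N/Oc2ccccc2)cc1Cl` is next: phenyl in place of cyanomethyl on an oxygen. For the measured compounds named here, no measured step covers a change on that oxygen; the step between compound 1 and compound 2 concerns a ring substituent and gives no direct guide. A step of a number 2.00 log units higher from compound 3 to compound 4 (beyond the scatter) upward is expected, beyond the scatter. Compound 4 is estimated at 5, within a range from 4.4 to 5.6.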

Compound 4, partition coefficient: 4.4
Compound 4: middle estimate off by 0.60 log units, on the high side; measured number inside the range.
By their numbers in this assay, from the lowest: compound 3; then compounds 4, 2 and 1 (each within the scatter of the next, the first and the last beyond it).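

In this assay, among the compounds shown here, the substituent on an oxygen whose other neighbour is double-bonded nitrogen proves sensitive to change: phenyl in place of cyanomethyl gives a number 1.40 log units higher from compound 3 to compound 4 (beyond the scatter), the only step measured at this position. The change removes a nitrile and adds an aromatic ring of carbon only, so the step cannot be assigned to either part alone. Nothing on hand bears on its cause.

Open, on these data alone, is how a benzyl group, a pyridine ring or a carboxylic acid on this oxygen would read in this assay. Also open, as far as these compounds go, is whether the same step holds on the core of compound 1.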